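Amino on the sulfoxide phenyl ring of compound 2

This account rests on a few compounds, and the source may have more. Where it says the series, first, only, none or still open, it means among the compounds named here.

In an assay for binding affinity to leukotriene B4 receptor 1 (Homo sapiens) (on this read-out lower numbers stand for stronger inhibition and higher numbers for weaker inhibition), compound 1 `CCCCCCCCC(O)/C=C/c1cccc(CC(O)c2cccc(C(=O)O)c2)n1` gives 1 nM and compound 3 `COc1ccc(CCCCCCOc2ccc(CC(O)c3cccc(C(=O)O)c3)nc2/C=C/C(=O)O)cc1` gives 165 nM. Compound 2 `COc1ccc(CCCCCCCCOc2ccc(C[S+]([O-])c3ccccc3)nc2/C=C/C(=O)O)cc1` gives 37 nM in this assay, the second highest of the three numbers: the number for compound 3 stands higher and that for compound 1 lower, both gaps beyond the usual scatter. Compound 4 `COc1ccc(CCCCCCCCOc2ccc(C[S+]([O-])c3cccc(N)c3)nc2/C=C/C(=O)O)cc1` differs from compound 2 by amino in place of hydrogen on an aromatic carbon. For the measured compounds named here, no measured pair carries this change, so no step for it is known; the expectation for compound 4 is a shift no larger than the scatter, in no firm direction, written as a 1.2-fold lower number from compound 2 to compound 4 (0.09 log units; within the scatter). Compound 4 is thus expected to give about 30 nM in this assay, with a range from 10 nM to 120 nM.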

Compound 4, inhibition constant: 4.7 nM
Estimate against measurement, compound 4: 6.4-fold (0.81 log units) above; the whole stated range lies above it.
By their numbers in this assay, from the lowest: compound 1; then compound 4; then compound 2; then compound 3.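

For the compounds shown here, the first measured step on this ring comes from phenyl to 3-aminophenyl on the sulfoxide side of the molecule: a 7.9-fold lower number from compound 2 to compound 4 (0.90 log units; beyond the scatter) in this assay. The change adds a single heavy atom, yet the step lies beyond the scatter, so this aromatic carbon is not indifferent to substitution. With one pair, this holds for amino at this place only.

Open is whether a hydroxyl, a methyl or an acetamide at the same carbon would give a step of like size, and nothing shown explains this one.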